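Swapping an anilino arm for a benzyl(methyl)amino arm

The source may report more compounds than this note shows. Statements on the series, on what has been measured and on what is new or still open speak of the compounds shown alone.

Measured so far:
Compound 1, `Cc1cc(NNC(N)=S)nc(SCc2nc3ccccc3[nH]2)n1`, in a functional assay on PC-3 cells (Homo sapiens) for cytotoxicity, read by MTT assay, with a stated time of 72 h (a lower number here means a stronger inhibitor, a higher number a weaker inhibitor), a limit of > 100000 nM.
Compound 2, `Cc1ccc(Nc2cc(C)nc(SCc3nc4ccccc4[nH]3)n2)cc1`, in this assay 56000 nM.

Going by the values given here, compound 2 holds the only actual number here; the other value, that of compound 1, is a limit (the limit of > 100000 nM in this assay, at which 1 of the 2 values shown sits). Compound 3, `Cc1cc(N(C)Cc2ccccc2)nc(SCc2nc3ccccc3[nH]2)n1`, carries benzyl(methyl)amino in place of (4-methylphenyl)amino on an aromatic carbon. Among the compounds with values here, the sole measured step, an at least 1.7-fold lower number from compound 1 to compound 2 (0.25 log units; that floor lies within the scatter), swapped a group without a ring for one with a ring and sits within the scatter, so it gives little guidance. For compound 3 a change no larger than the scatter is expected, a 1.1-fold higher number from compound 2 to compound 3 (0.03 log units; within the scatter). Compound 3 is therefore estimated at 60000 nM, between 20000 nM and 200000 nM.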

Compound 3, half-maximal inhibitory concentration: > 100000 nM
Compound 3 was reported as a limit; the forecaster's own chance of this, stated with the estimate: 35%; middle value at least 1.6-fold (0.22 log units) away from the limit.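

Compound 3 is reported only as a limit: the limit of > 100000 nM in this assay, at which 2 of the 3 values shown sit. Putting benzyl(methyl)amino in place of (4-methylphenyl)amino, which removes the hydrogen-bond donor at this aromatic carbon, gives an at least 1.7-fold higher number from compound 2 to compound 3 (0.25 log units; that floor lies within the scatter), so this swap brings no lower number, although the floor of the step does not prove a real loss. Compound 1 and compound 3 are both limits, so the step between them cannot be read.

Going by these compounds, how far the true value of compound 3 lies from its limit remains open. So does how a piperidine at this carbon, or a carboxylic acid on the phenyl ring, would read in this assay.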